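Replacing the Hydroxycarbamoyl Phenyl in an Azetidine Sulfonamide Series

The compounds below may be only part of what the source reports. "The series", "measured", "known", "first", "only" and "open" are said of these compounds alone.

Measured compounds:
compound 1 `O=C(NO)c1ccc(N(Cc2ccc(C3CCCCC3)cc2)C(=O)[C@H]2CCN2S(=O)(=O)c2c(F)c(F)c(F)c(F)c2F)cc1O`, 9700 nM
compound 2 `O=C(NO)c1ccc(N(Cc2ccc(C3CCOCC3)cc2)C(=O)[C@H]2CCN2S(=O)(=O)c2c(F)c(F)c(F)c(F)c2F)cc1O`, "not determined" (no result reported)
compound 3 `O=C(NO)c1ccc(N(Cc2ccc(C3CCCCC3)cn2)C(=O)[C@H]2CCN2S(=O)(=O)c2c(F)c(F)c(F)c(F)c2F)cc1O`, "not determined" (no result reported)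

Compound 1 `O=C(NO)c1ccc(N(Cc2ccc(C3CCCCC3)cc2)C(=O)[C@H]2CCN2S(=O)(=O)c2c(F)c(F)c(F)c(F)c2F)cc1O` was tested in a functional assay on MCF7 cells (Homo sapiens) for antiproliferative activity, with a stated time of 72 h (on this read-out higher numbers stand for an effect only at larger amounts of compound and lower numbers for an effect already at smaller amounts), and gives 9700 nM, a weak effect. Compound 2 `O=C(NO)c1ccc(N(Cc2ccc(C3CCOCC3)cc2)C(=O)[C@H]2CCN2S(=O)(=O)c2c(F)c(F)c(F)c(F)c2F)cc1O` has no single number in this assay; its entry reads "not determined" (no result reported). Among the measured compounds shown here, compound 3 `O=C(NO)c1ccc(N(Cc2ccc(C3CCCCC3)cn2)C(=O)[C@H]2CCN2S(=O)(=O)c2c(F)c(F)c(F)c(F)c2F)cc1O` likewise stands without a single number in this assay, its entry reading "not determined" (no result reported), so nothing measured fixes its place; the only number in the whole set is that of compound 1.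

Compound 4 `Cn1ccc2cc(N(Cc3ccc(C4CCCCC4)cn3)C(=O)[C@H]3CCN3S(=O)(=O)c3c(F)c(F)c(F)c(F)c3F)ccc2c1=O` differs from compound 3 by the change (a group of 12 heavy atoms (10 carbon, 1 nitrogen, 1 oxygen; one six-membered aromatic ring of carbon only, one six-membered aromatic ring with 1 hetero atom) in place of a group of 11 heavy atoms (7 carbon, 1 nitrogen, 3 oxygen; one six-membered aromatic ring of carbon only), on an amide-type nitrogen). The group that leaves, 3-hydroxy-4-(hydroxycarbamoyl)phenyl, is the part that compound 1, compound 2 and compound 3 all share on the amide-type nitrogen, and the group that enters has no common name.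

No measured pair brackets this change, so the expected size of the step in this assay cannot be taken from any number shown; with only the weak value of compound 1 as an anchor, a shift in the direction of a larger amount of compound is expected, and a result that is only a limit is plausible. Compound 4 is estimated at 20000 nM, with a range from 4000 nM to 100000 nM.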

Compound 4, half-maximal effective concentration: 2800 nM
Compound 4: the middle estimate sits 7.1-fold (0.85 log units) above what was measured; measured number outside the range, below it.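

Among the compounds shown here, compound 3 has no single number, so compound 4, at [ 2800 nM ], yields no step from compound 3. The compounds shown leave open how far replacing the 3-hydroxy-4-(hydroxycarbamoyl)phenyl group on the amide-type nitrogen moves antiproliferative activity. No measurement shown offers an explanation for the result of compound 4.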